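A fluoro for tert-butyl swap on the aryl ring

The source may report more compounds than this note shows. Statements on the series, on what has been measured and on what is new or still open speak of the compounds shown alone.

Compound 2 `CC(C)(C)c1ccc(-c2cn(Cc3ccccc3)c3c2CNCC3)cc1` holds the highest of the two numbers measured in an assay on HEK293 cells for displacement of a labelled ligand from 5-hydroxytryptamine receptor 7 (Rattus norvegicus), with a stated time of 60 min (on this read-out lower numbers stand for stronger inhibition and higher numbers for weaker inhibition), giving 10000 nM; its nearest neighbour, compound 1 `O=[N+]([O-])c1ccc(-c2cn(Cc3ccccc3)c3c2CNCC3)cc1`, gives 450 nM. Among the compounds with values here, the one measured step, a 22-fold higher number from compound 1 to compound 2 (1.35 log units; beyond the scatter), is the only one that bears on the new change, (fluoro in place of tert-butyl on an aromatic carbon), which gives compound 3 `Fc1ccc(-c2cn(Cc3ccccc3)c3c2CNCC3)cc1`. Within the data shown here, no measured step covers fluoro itself, so the expected step is a 6.7-fold lower number from compound 2 to compound 3 (0.82 log units; beyond the scatter), directed toward a lower number with wide uncertainty. Compound 3 is therefore estimated at 1500 nM, with a range from 300 nM to 7000 nM.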

Compound 3, inhibition constant: 45 nM
Compound 3: middle estimate off by 33-fold (1.52 log units), on the high side; measured number outside the range, below it.
By their numbers in this assay, from the lowest: compound 3; then compound 1; then compound 2.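

In this assay the change to fluoro gives a 220-fold lower number from compound 2 to compound 3 (2.35 log units; beyond the scatter) when it replaces tert-butyl and a 10-fold lower number from compound 1 to compound 3 (1.00 log units; beyond the scatter) when it replaces nitro. Compound 3 thus holds the lowest number of the three, so a low number at this position does not depend on nitro, which had stood lowest until now. Nothing available accounts for these steps. Still open, from the compounds shown here alone, is how chloro, methoxy or an amine would compare with fluoro at this position, and whether the same order would hold with another group in place of benzyl on the shared core.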